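Carbonyl substituent swap: 2-methoxyphenyl to 2,6-difluorophenyl

The source may hold more compounds than are shown below. What is called first, only, known or untested is meant among the compounds shown, and "the series" means these compounds.

Measured so far:
Compound 2 `COc1ccccc1C(=O)Nc1c[nH]nc1C(=O)NCc1ccc(C(=O)Nc2ccccc2N)cc1`: 8130 nM
Compound 1 `O=C(NO)c1ccc(CNC(=O)c2n[nH]cc2NC(=O)c2ccccc2F)cc1`: 6610 nM

In a functional assay on HeLa cells (Homo sapiens) for inhibition, read by CCK-8 assay, with a stated time of 72 h (a lower number here means a stronger inhibitor, a higher number a weaker inhibitor), compound 2 gives 8130 nM, the higher of the two numbers shown; compound 1 gives 6610 nM, and the gap between the two lies within the scatter, so no order between them is drawn. Compound 3 `Nc1ccccc1NC(=O)c1ccc(CNC(=O)c2n[nH]cc2NC(=O)c2c(F)cccc2F)cc1` differs from compound 2 by 2,6-difluorophenyl in place of 2-methoxyphenyl on a carbonyl carbon. For the measured compounds named here, no step between measured compounds is known, so nothing in the numbers points to a direction. The step of a 1.2-fold lower number from compound 2 to compound 3 (0.06 log units; within the scatter) is expected to stay within the scatter. Compound 3 is therefore expected to give 7000 nM in this assay, with a range from 2500 nM to 20000 nM.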

Compound 3, half-maximal inhibitory concentration: 4480 nM
For compound 3 the middle estimate is 1.6-fold (0.19 log units) above the measured one, within the range that was stated.
By their numbers in this assay, from the lowest: compounds 3, 1 and 2 (each within the scatter of the next).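

In this assay, for the compounds shown here, 2,6-difluorophenyl in place of 2-methoxyphenyl on a carbonyl carbon gives a 1.8-fold lower number from compound 2 to compound 3 (0.26 log units; within the scatter) and is the first single-place step. At this position, the loss of the hydrogen-bond acceptor that comes with 2-methoxyphenyl gives no separable difference in this read-out. No supporting measurement bears on the interpretation of this result.

Still open, from the compounds shown here alone, is whether an unsubstituted phenyl or a cyclohexyl group on this carbonyl carbon would also stay within the scatter. Going by these compounds, the effect of a basic amine on that ring also remains open.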